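A few compounds are considered here, and "the series" means these few. Any claim that something is new, unique, unknown or untested is made for them only; others in the source may bear on it.

Working notes on the series. Compound 1 `CC(=O)c1cnc(N2CCC(c3coc4c(N5CCc6cc(S(C)(=O)=O)ccc65)ncnc34)CC2)nc1` is the reference for the step under consideration. Going by the values given here, in a functional assay on cells for agonist activity at Glucose-dependent insulinotropic receptor (Homo sapiens), read by a luciferase reporter, with a stated time of 4 h (on this read-out higher numbers stand for an effect only at larger amounts of compound and lower numbers for an effect already at smaller amounts), compound 1 gives 78 nM, the lowest of the two numbers measured so far, but only within the scatter of the other: compound 2 `CC(C)(C)OC(=O)N1CCC(c2csc3c(Nc4ccc(S(C)(=O)=O)cc4F)ncnc23)CC1`, which already carries a tert-butoxycarbonyl on its ring amine nitrogen, gives 79 nM in this assay, so no order between compound 1 and compound 2 can be read from these two values.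

Compound 3 `CC(C)(C)OC(=O)N1CCC(c2coc3c(N4CCc5cc(S(C)(=O)=O)ccc54)ncnc23)CC1` is not yet measured. It differs from compound 1 in one place: tert-butoxycarbonyl in place of 5-acetylpyrimidin-2-yl on an amine nitrogen in a ring.

Among the compounds with values here, no measured pair in the set shows this exchange directly. Since compound 2 with the same entering group gives 79 nM, the step from compound 1 to compound 3 is expected to be small, a 1.4-fold higher number from compound 1 to compound 3 (0.15 log units; within the scatter), in either direction and not clearly beyond the scatter. For compound 3 the estimate in this assay is 110 nM, with a range from 40 nM to 300 nM.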

Compound 3, half-maximal effective concentration: 53 nM
Compound 3: the middle estimate sits 2.1-fold (0.32 log units) above what was measured, and the stated range covers the measured number.
By their numbers in this assay, from the lowest: compounds 3, 1 and 2 (each within the scatter of the next).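

On the amine nitrogen in a ring, 5-acetylpyrimidin-2-yl and tert-butoxycarbonyl can now be compared directly on one shared core, and in this assay the exchange gives a 1.5-fold lower number from compound 1 to compound 3 (0.17 log units; within the scatter) and stays within the scatter. This pair therefore gives no order between the two groups, and a six-membered aromatic ring with 2 hetero atoms and a group with no ring read alike at this position. Nothing measured here bears on why the two groups read alike.

Going by these compounds, whether a benzyl group, a methanesulfonyl group or a carboxylic acid on this nitrogen would move the number beyond the scatter remains open. Also open, on these data alone, is whether 5-acetylpyrimidin-2-yl and tert-butoxycarbonyl also read alike on the core of compound 2.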